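This account rests on a few compounds, and the source may have more. Where it says the series, first, only, none or still open, it means among the compounds named here.

Compound 1 (`COc1cc(-n2ncnc2-c2ccc(C)cc2)cc(OC)c1OC`) gives 250 nM
Compound 2 (`COc1cc(-n2ncnc2-c2cccc(Cl)c2)cc(OC)c1OC`) gives > 10000 nM as a limit of the assay
Compound 3 (`COc1cc(-n2ncnc2-c2ccc(SC)cc2)cc(OC)c1OC`) gives 150 nM

Among the compounds with values here, in a functional assay on HeLa cells (Homo sapiens) for antiproliferative activity, read by MTT assay, with a stated time of 72 h (a higher number here means a weaker inhibitor, a lower number a stronger inhibitor), compound 3 and compound 1 hold the only actual numbers, and these two cannot be told apart (a 1.7-fold lower number from compound 1 to compound 3 (0.22 log units; within the scatter)). Compound 4 (`COc1cc(-n2ncnc2-c2ccc(F)cc2)cc(OC)c1OC`) has fluoro in place of methylsulfanyl on an aromatic carbon, para to a large group (fluoro in place of methylsulfanyl on an aromatic carbon). The nearest guide is the swap between compound 1 and compound 3 at that same place, which stayed within the scatter. The two large steps (an at least 40-fold higher number from compound 1 to compound 2 (1.60 log units; beyond the scatter) and an at least 66-fold lower number from compound 2 to compound 3 (1.82 log units; beyond the scatter)) both involve the 3-chlorophenyl of compound 2 and show that a change in this group can cost heavily. A moderately higher number is therefore expected, beyond the scatter but short of the limit seen for compound 2. The expected step is a rise (a 5.3-fold higher number from compound 3 to compound 4 (0.73 log units; beyond the scatter)). The estimate for compound 4 is 800 nM (expected range 150 nM to 6000 nM).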

Compound 4, half-maximal inhibitory concentration: > 10000 nM
Compound 4 gave a limit, no number; the forecaster's own chance of this, stated with the estimate: 15%; middle value at least 12-fold (1.09 log units) away from the limit.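

Methyl and methylsulfanyl could be exchanged at this place with no readable change, but fluoro cannot take their place: there is an at least 66-fold higher number from compound 3 to compound 4 (1.82 log units; beyond the scatter), and an at least 40-fold higher number from compound 1 to compound 4 (1.60 log units; beyond the scatter). A change at this one place can therefore lift a compound to the top of the readable range, which compound 2, with its chloro elsewhere on the ring, did not show. The value of compound 4 is a limit, so the step from compound 2 cannot be read: the limit of > 10000 nM in this assay, at which 2 of the 4 values shown sit.

Going by these compounds, whether an ethyl or an amine at this place would keep the activity of compound 1 and compound 3 stays open.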